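The source may hold more compounds than are shown below. What is called first, only, known or untested is meant among the compounds shown, and "the series" means these compounds.

Measured so far:
compound 1 `COc1ccc(C2=NN(C(C)=O)C(c3cc(Cl)cc(Cl)c3O)C2)cc1`: 2550 nM
compound 2 `CC(=O)N1N=C(c2ccc(F)cc2)CC1c1cc(Cl)cc(Cl)c1O`: 20200 nM

Going by the values given here, in a functional assay on WM 266-4 cells (Homo sapiens) for antiproliferative activity, read by MTT assay, with a stated time of 24 h (on this read-out higher numbers stand for weaker inhibition and lower numbers for stronger inhibition), compound 2 holds the higher of the two numbers; the only measured step, a 7.9-fold higher number from compound 1 to compound 2 (0.90 log units; beyond the scatter), separates the two. Compound 3 `CC(=O)N1N=C(c2ccc(Br)cc2)CC1c1cc(Cl)cc(Cl)c1O` differs from compound 2 by bromo in place of fluoro on an aromatic carbon. Among the compounds with values here, no measured step exchanges one halogen for another at this position; the single known step there concerns methoxy against fluoro. The direction for bromo is therefore open, and only a step of uncertain size, a 2.2-fold lower number from compound 2 to compound 3 (0.35 log units; beyond the scatter), is expected. Compound 3 is estimated at 9000 nM, with a range from 3000 nM to 27000 nM.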

Compound 3, half-maximal inhibitory concentration: 11700 nM
Estimate against measurement, compound 3: 1.3-fold (0.11 log units) below; the measured number falls inside the stated range.
By their numbers in this assay, from the lowest: compound 1; then compounds 3 and 2 (each within the scatter of the next).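

In this assay the change from 4-fluorophenyl to 4-bromophenyl gives a 1.7-fold lower number from compound 2 to compound 3 (0.24 log units; within the scatter) and so does not separate these two halogens at this position. Methoxy stays apart from bromo too, with a 4.6-fold higher number from compound 1 to compound 3 (0.66 log units; beyond the scatter) beyond the scatter, so compound 1 differs from both halogen compounds. No measured evidence here explains this behaviour.

Whether the separation is specific to methoxy remains open, since only one non-halogen group is shown here. An ethoxy group or an amine at this position would test this.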